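The compounds below may be only part of what the source reports. "The series", "measured", "known", "first", "only" and "open" are said of these compounds alone.

Compound 1 `O=S(=O)(Nc1ccc(F)c(Cl)c1)c1ccc(-c2cnc(C3CC3)o2)cc1` gives 260 nM in a functional assay on cells (leukaemia cell line, Homo sapiens) for inhibition, read by sulforhodamine B assay, with a stated time of 48 h; a higher number here means a weaker inhibitor of growth, a lower number a stronger inhibitor of growth.
Compound 2 `Cc1ccc(NS(=O)(=O)c2ccc(-c3cnc(C4CC4)o3)cc2)cc1C` gives 420 nM.
Compound 3 `COc1cc(NS(=O)(=O)c2ccc(-c3cnc(C4CC4)o3)cc2)ccc1F` gives 328 nM.

Compound 2 has the highest number of the three, yet the steps of a 1.6-fold higher number from compound 1 to compound 2 (0.21 log units; within the scatter) and a 1.3-fold lower number from compound 2 to compound 3 (0.11 log units; within the scatter) are both within the scatter, so the three compounds cannot be told apart. Compound 4 `Cc1cc(F)cc(NS(=O)(=O)c2ccc(-c3cnc(C4CC4)o3)cc2)c1` has not been measured. It differs from compound 2 by 3-fluoro-5-methylphenyl in place of 3,4-dimethylphenyl on a sulfonamide nitrogen. The two measured steps that swap the group on the sulfonamide nitrogen, a 1.6-fold higher number from compound 1 to compound 2 (0.21 log units; within the scatter) and a 1.3-fold lower number from compound 2 to compound 3 (0.11 log units; within the scatter), both stayed within the scatter, so a step of a 1.1-fold lower number from compound 2 to compound 4 (0.02 log units; within the scatter) within the scatter is expected here too. Compound 4 is therefore estimated at 400 nM in this assay, expected to fall between 200 nM and 800 nM.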

Compound 4, concentration for 50% growth inhibition: 138 nM
Compound 4: middle estimate off by 2.9-fold (0.46 log units), on the high side, outside the stated range (below it).
By their numbers in this assay, from the lowest: compounds 4, 1, 3 and 2 (each within the scatter of the next, the first and the last beyond it).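

Swapping the group on the sulfonamide nitrogen can shift the number in this assay: 3-fluoro-5-methylphenyl gives a 3.0-fold lower number from compound 2 to compound 4 (0.48 log units; beyond the scatter) and a 2.4-fold lower number from compound 3 to compound 4 (0.38 log units; beyond the scatter), the first steps at this position beyond the scatter. Against 3-chloro-4-fluorophenyl, the step is a 1.9-fold lower number from compound 1 to compound 4 (0.28 log units; within the scatter), so these two groups cannot be told apart. Nothing available here says why this change has the effect it does.

As far as these compounds go, it remains open whether the fluoro or the methyl group in 3-fluoro-5-methylphenyl matters more. From the compounds shown here alone, it is also open how an amine, a carboxylic acid or a longer chain on this aromatic ring would behave.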